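The compounds below may be only part of what the source reports. "The series", "measured", "known", "first", "only" and "open" are said of these compounds alone.

Measured so far:
- compound 1 `Cc1ccc(C2CC(=O)c3ccc(F)cc3O2)cc1`: 160 nM
- compound 2 `Fc1ccc(-c2cc(=S)c3ccc(F)cc3o2)cc1`: 6890 nM
- compound 3 `COc1ccc2c(c1)OC(c1ccccc1)CC2=O`: 1470 nM

Three compounds share a core in which a saturated ring bearing a carbonyl is fused to a benzene ring, and each carries an aryl group on the saturated ring. In an in vitro assay on BTI-TN-5B1-4 cells for inhibition of Amine oxidase [flavin-containing] B (Homo sapiens) (a lower number here means a stronger inhibitor, a higher number a weaker inhibitor), compound 1 gives 160 nM, the lowest of the three numbers. Compound 3 gives 1470 nM, a higher number that lies beyond the scatter of the method, and compound 2 gives 6890 nM, the highest number of the set and furthest from compound 1.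

Compound 4 `Cc1ccc([C@@H]2CC(=O)c3ccc(F)cc3O2)cc1` has not yet been measured. It differs from compound 1 in no atom or bond: the two compounds have the same atoms and bonds; at least one stereo element is drawn with a configuration in one of them and without one in the other: 1 of 1 stereo elements differ; a stereocentre at a saturated ring carbon is drawn without a configuration in compound 1 and S in compound 4. Compound 1 is thus drawn as a mixture of two mirror-image forms, and compound 4 is one of those forms alone. Going by the values given here, no pair of measured compounds shows what such a step does here. If the single form is the one that carries the activity of the mixture, the number should fall slightly; if it is the other form, the number could rise far beyond the scatter. The estimate for compound 4 is 150 nM, with a range from 50 nM to 1500 nM, which means an expected step of a 1.1-fold lower number from compound 1 to compound 4 (0.03 log units; within the scatter).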

Compound 4, half-maximal inhibitory concentration: 150 nM
The estimate for compound 4 equals the measured number at the digits printed; measured number inside the range.
By their numbers in this assay, from the lowest: compounds 4 and 1 (each within the scatter of the next); then compound 3; then compound 2.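

In this assay, taking the single S form in place of the mixture gives a 1.1-fold lower number from compound 1 to compound 4 (0.03 log units; within the scatter). Going by these compounds alone, this is the first view of what the configuration at this saturated ring carbon means for the number, and it rules out the case in which the S form is the poor partner of the pair, since such a form alone would have given a number far from that of the mixture. The step cannot be put down to any change in atoms or bonds, and the only difference at this position is the one in how the stereocentre is drawn: the fact that one of compounds 1 and 4 is drawn with a defined configuration and the other without, at the place where they differ

The mirror-image R form is not among these compounds, and a step within the scatter fits an R form that matches the S form as well as one that contributes little, so how far this position tells the two forms apart stays unknown. Also open, as far as these compounds go, are whether the same holds for the matching stereocentre in compound 3, and what an amine or a carboxylic acid on the aryl group of compound 4 would do to the number.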